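Aryl exchange at the chain end, compared across two cores

This account rests on a few compounds, and the source may have more. Where it says the series, first, only, none or still open, it means among the compounds named here.

Compound 1 `O=S(=O)(/C=C/c1ccc(F)cc1)Cc1ccc(Nc2ncnc3ccccc23)cc1` and compound 2 `O=S(=O)(/C=C/c1ccc(Cl)cc1Cl)Cc1ccc(Nc2ncnc3ccccc23)cc1` share one core and differ only at the far end of the chain. In a functional assay on OVCAR-8 cells (Homo sapiens) (on this read-out lower numbers stand for stronger inhibition of growth and higher numbers for weaker inhibition of growth), compound 1 gives 2000 nM, and compound 2 gives 4000 nM. The change between them is 4-fluorophenyl in place of 2,4-dichlorophenyl on a double-bonded chain carbon bound to a double-bonded chain carbon, and the step it made reads a 2.0-fold lower number from compound 2 to compound 1 (0.30 log units; within the scatter).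

Compound 3 `COc1cc2ncnc(Nc3ccc(CS(=O)(=O)/C=C/c4ccc(Cl)cc4Cl)cc3)c2cc1OC` carries the same 2,4-dichlorophenyl end on a second core; the difference between the two cores is not broken down here. In this assay, going by the values given here, compound 3 gives 2000 nM, the same figure as compound 1 and, like it, among the lowest of the three numbers so far.

Compound 4 `COc1cc2ncnc(Nc3ccc(CS(=O)(=O)/C=C/c4ccc(F)cc4)cc3)c2cc1OC` has not yet been measured. It differs from compound 3 by 4-fluorophenyl in place of 2,4-dichlorophenyl on a double-bonded chain carbon bound to a double-bonded chain carbon, the same change as from compound 2 to compound 1, made at the same place and with the same two groups. The pair on the first core therefore is the only reference for what to expect on the second core. Beside the earlier step, the new one is expected to be of like size, a 1.7-fold lower number from compound 3 to compound 4 (0.22 log units; within the scatter), because the earlier change gave a 2.0-fold lower number from compound 2 to compound 1 (0.30 log units; within the scatter) and the starting points of both pairs lie at comparable figures. In this assay compound 4 is accordingly estimated at 1200 nM, with a likely range from 500 nM to 3000 nM; the estimate rests on one measured pair only.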

Compound 4, concentration for 50% growth inhibition: > 100000 nM
Compound 4 was reported as a limit; the forecaster's own chance of this, stated with the estimate: 3%; middle value at least 83-fold (1.92 log units) away from the limit.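

In the series, 4-fluorophenyl in place of 2,4-dichlorophenyl on the core of compound 3 gives an at least 50-fold higher number from compound 3 to compound 4 (1.69 log units; beyond the scatter) in this assay, and the change does not carry over from one core to the other at comparable size: the same change on two cores in this assay, a 2.0-fold lower number (0.30 log units; within the scatter) from compound 2 to compound 1 and an at least 50-fold higher number (1.69 log units; beyond the scatter) from compound 3 to compound 4, at least 100-fold (2.00 log units) apart, beyond the scatter of two such steps

In this assay compound 4 is reported at > 100000 nM, which is a limit of the assay and not a number: the limit of > 100000 nM in this assay, at which 1 of the 4 values shown sits.

Going by these compounds alone, with one pair on each core, the step on one core proved no guide to the step on the other, but this does not show what in the two cores produces the gap, nor whether the same would hold for any other pair of end groups.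

The compounds shown leave open whether the result on the core of compound 3 follows from the fluorine atom entering or from the two chlorine atoms leaving. A 4-chlorophenyl or a 2-chlorophenyl end, or a plain phenyl end, set on both cores would begin to separate these readings and would show whether the sharp step belongs to this one pair of end groups alone.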